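Replacing hydroxy with methoxy on the cyclohexyl ring

A few compounds are considered here, and "the series" means these few. Any claim that something is new, unique, unknown or untested is made for them only; others in the source may bear on it.

Compound 1 `N#Cc1cnc(NCc2cnccc2C(F)(F)F)cc1N[C@H]1C[C@H](O)C1` gives 82%
Compound 2 `N#Cc1cnc(NCc2cnccc2C(F)(F)F)cc1N[C@H]1CC[C@H](O)CC1` gives 25%

In an ADME assay on S9 fraction from liver (Rattus norvegicus) for metabolic stability, with a stated time of 1 h (on this read-out lower numbers stand for a less stable compound and higher numbers for a more stable compound), compound 2 gives 25% and so holds the lower of the two numbers. Compound 3 `CO[C@H]1CC[C@@H](Nc2cc(NCc3cnccc3C(F)(F)F)ncc2C#N)CC1` has not been measured yet. It carries 4-methoxycyclohexyl in place of 4-hydroxycyclohexyl on a nitrogen on an aromatic ring. Going by the values given here, the one measured step at that place (a number 57 percentage points lower from compound 1 to compound 2 (beyond the scatter)) was large, but it put 4-hydroxycyclohexyl in place of 3-hydroxycyclobutyl. Among the compounds with values here, no measured pair compares methoxy with hydroxy on the same ring, so that step bears on this change only loosely, and no step beyond the scatter is expected, though with wide uncertainty. The expected step is small (a number 3 percentage points lower from compound 2 to compound 3 (within the scatter)). Compound 3 is estimated to give 22% (expected range 5% to 45%).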

Compound 3, percent of the compound remaining: 1%
Compound 3: the middle estimate sits 21 percentage points above what was measured; the measured number lies below the stated range.
By their numbers in this assay, from the lowest: compound 3; then compound 2; then compound 1.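

In this assay, methoxy in place of hydroxy on the cyclohexyl ring is not a neutral change at this place on a nitrogen on an aromatic ring: 4-methoxycyclohexyl in place of 4-hydroxycyclohexyl gives a number 24 percentage points lower from compound 2 to compound 3 (beyond the scatter). With the ring held the same, this pair shows that the number responds to the group on the ring as well as to the ring itself, and the two changes together, 4-methoxycyclohexyl in place of 3-hydroxycyclobutyl, give a number 81 percentage points lower from compound 1 to compound 3 (beyond the scatter). Nothing measured here accounts for either step.

Going by these compounds, it remains open whether methoxy would lower the number as far on the cyclobutyl ring as it does on the cyclohexyl ring. On these data alone, how an amine or a fluorine in place of the hydroxy on the cyclohexyl ring would read also stays unknown.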